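A few compounds are considered here, and "the series" means these few. Any claim that something is new, unique, unknown or untested is made for them only; others in the source may bear on it.

Measured so far in a functional assay on T47D cells (Homo sapiens) for inhibition, read by sulforhodamine B assay, with a stated time of 48 h; a lower number here means that less compound is tolerated, a higher number that more compound is tolerated:
- compound 1 `COc1cc2cc(Oc3ccc(NC(=O)Nc4cccc(C(F)(F)F)c4)cc3)c(C)nc2cc1OC`: > 50000 nM
- compound 2 `COc1cc2cc(Oc3ccc(NC(=O)Nc4ccc(Cl)c(C(F)(F)F)c4)cc3)c(C)nc2cc1OC`: > 32500 nM

Both of these values are limits of this assay, not numbers. Compound 1 reaches > 50000 nM, which is a limit. Compound 2 reaches > 32500 nM, again a limit. Among the compounds with values here, compound 2 therefore stands at a limit, and the one other value shown is a limit as well, so the step that the two limits leave unreadable from compound 1 to compound 2 cannot be read; the two limits the limit of > 32500 nM in this assay, at which 1 of the 2 values shown sits, and the limit of > 50000 nM in this assay, at which 1 of the 2 values shown sits, only show that neither compound reduced cell growth by half within the tested range.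

Compound 3 `COc1cc2cc(Oc3ccc(NC(=O)Nc4ccc(Cl)c(Cl)c4)cc3)c(C)nc2cc1OC` differs from compound 2 in one place: chloro in place of trifluoromethyl on an aromatic carbon. Within the data shown here, the only measured step that bears on this change, the step from compound 1 to compound 2, is itself unreadable, so no size or direction can be expected from it. What the two limits do suggest is that compound 3 is expected to reach the limit too, with a step that the limit leaves unreadable from compound 2 to compound 3 that is expected to carry no readable meaning. Compound 3 is estimated at 50000 nM, between 20000 nM and 100000 nM, most likely reported only as a limit.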

Compound 3, concentration lethal to 50% of the cells: 84700 nM
Estimate against measurement, compound 3: 1.7-fold (0.23 log units) below, and the stated range covers the measured number.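

Compound 1 and compound 2 are known only as limits in this assay. Compound 3 gives 84700 nM. The steps from compound 1 and from compound 2 to compound 3 cannot be read. On these data alone, whether chloro in place of trifluoromethyl changes how much compound is tolerated, and in which direction, stays open.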